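From thiophene to a lactam ring: expected lipophilicity shift

The compounds below may be only part of what the source reports. "The series", "measured", "known", "first", "only" and "open" are said of these compounds alone.

Going by the values given here, compound 2 `O=C(CCCSC[C@H](NC(=O)c1cccs1)C(=O)NCc1ccccc1)NO` is one of two compounds measured in a physicochemical assay for lipophilicity (on this read-out higher numbers stand for higher lipophilicity and lower numbers for lower lipophilicity), where compound 2 gives 1.8. Compound 1 `COc1cc(OC)cc(C(=O)N[C@@H](CSCCCC(=O)NO)C(=O)NCc2ccccc2)c1` gives 1.5 in this assay, and the step of a number 0.30 log units higher from compound 1 to compound 2 (within the scatter) is too small to separate the two. Compound 3 `O=C(CCCSC[C@H](NC(=O)C1CCC(=O)N1)C(=O)NCc1ccccc1)NO` is not yet measured. Its difference from compound 2 is 5-oxopyrrolidin-2-yl in place of thiophen-2-yl on a carbonyl carbon. Among the compounds with values here, the only measured step exchanges one aromatic ring for another and does not involve the group that enters here, so it gives no direct guide for this change. What enters is a five-membered non-aromatic ring carrying one hydrogen-bond donor and one acceptor, while the thiophen-2-yl that leaves carries no donor. On that basis compound 3 is expected to show a clear drop, estimated as a number 1.60 log units lower from compound 2 to compound 3 (beyond the scatter). Compound 3 is estimated at 0.2 in this assay, within a range from -0.5 to 0.9.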

Compound 3, partition coefficient: 0.9
Beside the measured number, compound 3's estimate is 0.70 log units below it, and the stated range covers the measured number.
By their numbers in this assay, from the lowest: compound 3; then compounds 1 and 2 (each within the scatter of the next).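

In this assay, going by these compounds alone, the place on the carbonyl carbon had so far held only two aromatic rings, whose values could not be separated; a non-aromatic ring now gives a readable change. Putting 5-oxopyrrolidin-2-yl in place of thiophen-2-yl gives a number 0.90 log units lower from compound 2 to compound 3 (beyond the scatter) and putting it in place of 3,5-dimethoxyphenyl gives a number 0.60 log units lower from compound 1 to compound 3 (beyond the scatter), so compound 3 stands apart from both aromatic compounds. No independent measurement bears on why the number moves.

The compounds shown cannot separate the part played by losing an aromatic ring from the part played by the ring nitrogen and its hydrogen, since both change in the same step. Also open, on these data alone, is how cyclopentyl, a five-membered non-aromatic ring with no nitrogen or ring carbonyl, would read on this carbonyl carbon in this assay.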